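The source may report more compounds than this note shows. Statements on the series, on what has been measured and on what is new or still open speak of the compounds shown alone.

Two compounds of this series have numbers in a physicochemical assay for lipophilicity; a higher number here means a more lipophilic compound, a lower number a more polar compound. Compound 1 `COc1ccc(C2SCC(=O)N2NC(=O)CNC(=O)c2ccccc2)cc1OC` gives 1.85 in this assay, and compound 2 `O=C(CNC(=O)c1ccccc1)NN1C(=O)CSC1c1cccc(Cl)c1` gives 2.8 in this assay. Among the compounds with values here, compound 2 stands at the higher of the two numbers; the gap to compound 1, the only other measured compound, lies beyond the scatter of the method. Compound 3 `O=C(CNC(=O)c1ccccc1)NN1C(=O)CSC1c1ccc(Cl)cc1` is not yet measured in this assay. It differs from compound 2 in one place: 4-chlorophenyl in place of 3-chlorophenyl on a saturated ring carbon. Within the data shown here, the two have the same atoms, joined differently, and no pair of measured compounds shows a step of this kind. For such a change no step beyond the scatter in this assay is expected in either direction, so the estimated step is no change at the digits printed from compound 2 to compound 3 (within the scatter). Compound 3 is accordingly expected to give about 2.8 in this assay, with a range from 2.5 to 3.1.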

Compound 3, partition coefficient: 2.87
Compound 3: the middle estimate sits 0.07 log units below what was measured, and the stated range covers the measured number.
By their numbers in this assay, from the lowest: compound 1; then compounds 2 and 3 (each within the scatter of the next).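

In this assay, 4-chlorophenyl in place of 3-chlorophenyl on the saturated ring carbon gives a number 0.07 log units higher from compound 2 to compound 3 (within the scatter). Within the data shown here, this is the first step of its kind: the atoms stay the same and only their joining changes, and at this position the read-out does not separate the two chlorophenyl groups. Nothing available bears on a reason for this result.

The finding rests on a single pair and holds only for these two chlorophenyl groups on this carbon. Still open, from the compounds shown here alone, is whether a phenyl ring carrying an amine or a carboxylic acid at this position would give a step beyond the scatter, and whether the same insensitivity would hold for such groups when they are joined differently to that ring.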